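A few compounds are considered here, and "the series" means these few. Any claim that something is new, unique, unknown or untested is made for them only; others in the source may bear on it.

Measured so far:
- compound 1 `COc1ccc(/C=C\C(=O)O)c(OCc2cn(-c3cccc(C#N)c3)nn2)c1CC=C(C)C`: in a functional assay on T47D cells (Homo sapiens) for cytotoxicity, read by MTT assay, with a stated time of 24 h (a lower number here means a stronger inhibitor, a higher number a weaker inhibitor), compound 1 gives 19200 nM
- compound 2 `COc1ccc(/C=C\C(=O)O)c(OCc2cn(-c3ccccc3I)nn2)c1CC=C(C)C`: in this assay compound 2 gives "not determined" (no result reported)

Within the data shown here, compound 2 stands on no number in this assay: the measurement is absent, so nothing is known of where it sits against compound 1, and no step between the two can be stated. The only anchor in this small set is compound 1, whose value in this assay is weak.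

Compound 3 `COc1ccc(/C=C\C(=O)O)c(OCc2cn(-c3ccc(C#N)cc3)nn2)c1CC=C(C)C` is not yet measured. It differs from compound 2 by the change (4-cyanophenyl in place of 2-iodophenyl on an aromatic nitrogen), that is, 4-cyanophenyl in place of 2-iodophenyl on an aromatic nitrogen. Among the measured compounds shown here, compound 3 also shares with compound 1 the nitrile on the phenyl ring, differing only in the place of that nitrile on the ring; no step between them is available.

For the measured compounds named here, with no measured step, no direction can be argued. The expectation is that compound 3 lands near compound 1 in this assay, with weak inhibition and wide uncertainty. Compound 3 is estimated at 20000 nM, expected within 6000 nM to 70000 nM in this assay.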

Compound 3, half-maximal inhibitory concentration: 10200 nM
Beside the measured number, compound 3's estimate is 2.0-fold (0.29 log units) above it; the range from low to high includes it.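

Notes on the aryl group on the triazole nitrogen: exchanging 3-cyanophenyl for 4-cyanophenyl gives a 1.9-fold lower number from compound 1 to compound 3 (0.27 log units; within the scatter) in this assay, so this pair offers the first readable step at this position, and the two placements of the nitrile on the phenyl ring cannot be told apart. Both nitrile-bearing compounds therefore remain in the same weak range in this assay, with compound 1 at 19200 nM and compound 3 at 10200 nM, and the pair gives no ground for preferring either placement. The step from 2-iodophenyl to 4-cyanophenyl cannot be read, as compound 2 has no number, and no supporting evidence is available to bear on this result.

The compounds shown leave open whether any substituent other than the nitrile on this phenyl ring, such as an amine or a carboxylic acid, would move the number beyond the scatter in this assay. Also open, as far as these compounds go, is how a longer chain between the aromatic nitrogen and the phenyl ring would read, and whether the weak level belongs to the shared core rather than to this position.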